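A few compounds are considered here, and "the series" means these few. Any claim that something is new, unique, unknown or untested is made for them only; others in the source may bear on it.

Measured compounds:
compound 1 `O=C([C@@H]1C[C@H](NCc2ccccc2)CN1)N1CCSC1` — 171 nM
compound 2 `CN(Cc1ccc(C#N)cc1)[C@@H]1CN[C@H](C(=O)N2CCSC2)C1` — 13.6 nM
compound 3 `CCCCN(Cc1ccc(C#N)cc1)[C@@H]1CN[C@H](C(=O)N2CCSC2)C1` — 5 nM

In an assay on a cell-free system (plasma) for inhibition of Dipeptidyl peptidase 4 (Rattus norvegicus), read by fluorescence (on this read-out higher numbers stand for weaker inhibition and lower numbers for stronger inhibition), compound 3 gives the lowest number of the three, with compound 2 nearest and compound 1 furthest away. Compound 4 `CCOC(=O)CN(Cc1ccc(C#N)cc1)[C@@H]1CN[C@H](C(=O)N2CCSC2)C1` differs from compound 3 in one place: ethoxycarbonyl in place of propyl on a saturated chain carbon bound to an amine nitrogen. Going by the values given here, the only measured step that bears on this position is a 2.7-fold lower number from compound 2 to compound 3 (0.43 log units; beyond the scatter), a modest gain on adding the chain. Among the compounds with values here, no measured step tells how an ester-bearing chain in this position behaves, so the expected change is set near the size of that earlier step, with uncertainty in either direction. Compound 4 is therefore estimated to land close to compound 3, at 8 nM, within a range of 3 nM to 25 nM, a step of a 1.6-fold higher number from compound 3 to compound 4 (0.20 log units; within the scatter) that is expected to stay within or only just beyond the scatter.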

Compound 4, half-maximal inhibitory concentration: 15.3 nM
Compound 4: middle estimate off by 1.9-fold (0.28 log units), on the low side; low and high end bracket the measured number.
By their numbers in this assay, from the lowest: compound 3; then compounds 2 and 4 (each within the scatter of the next); then compound 1.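

The gain from lengthening the chain on the amine nitrogen does not hold for every chain: ethoxycarbonyl in place of propyl gives a 3.1-fold higher number from compound 3 to compound 4 (0.49 log units; beyond the scatter) in this assay and so gives back what the butyl chain had added. Ethoxycarbonyl in place of hydrogen gives a 1.1-fold higher number from compound 2 to compound 4 (0.05 log units; within the scatter) and so cannot be told apart from the methyl group. As far as these compounds go, whether a carboxylic acid in place of the ester, an amine at the chain end or a longer alkyl chain would keep the low number stays open. Nothing measured here accounts for the difference between these chains.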